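The source may report more compounds than this note shows. Statements on the series, on what has been measured and on what is new or still open speak of the compounds shown alone.

Of the compounds shown here, three of one shared core have been tested in an ADME assay on cells (Peritoneal macrophage, Mus musculus, strain Balb/c) for cytotoxicity, read by resazurin assay, with a stated time of 72 h; on this read-out higher numbers stand for lower toxicity in this test and lower numbers for higher toxicity in this test. Compound 1 `N/C(=N\O)c1ccc(C2=C(S(=O)(=O)c3ccc(F)cc3)CC3(CCCCC3)O2)cc1` gives 92900 nM. Compound 2 `CC1(Cc2cccc(/C(N)=N/O)c2)CC(S(=O)(=O)c2ccc(F)cc2)=C(c2ccc(/C(N)=N/O)cc2)O1` gives 50200 nM. Compound 3 `CC1(Cc2ccc(C(F)(F)F)cc2)CC(S(=O)(=O)c2ccc(F)cc2)=C(c2ccc(/C(N)=N/O)cc2)O1` gives 103000 nM, the highest of the three numbers, though its gap to compound 1 lies within the scatter and only its gap to compound 2 lies beyond it.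

Compound 4 `CC1(Cc2cccc([N+](=O)[O-])c2)CC(S(=O)(=O)c2ccc(F)cc2)=C(c2ccc(/C(N)=N/O)cc2)O1` has not been measured. It differs from compound 3 in one place: 3-nitrophenyl in place of 4-(trifluoromethyl)phenyl on a saturated chain carbon bound to a saturated ring carbon. Among the measured compounds shown here, only one measured step touches this position: a 2.1-fold higher number from compound 2 to compound 3 (0.31 log units; beyond the scatter), which swapped an amidoxime-bearing ring for the trifluoromethyl-bearing one on the same chain carbon. For the measured compounds named here, the nitrophenyl of compound 4 is neither of these two groups, so the step from compound 3 to compound 4 has no direct precedent. Going by the values given here, since the one measured step at this place, a 2.1-fold higher number from compound 2 to compound 3 (0.31 log units; beyond the scatter), was modest and the two numbers bracket a narrow band, the nitrophenyl is expected to land within that band, most likely a little under compound 3. Compound 4 is therefore estimated at 75000 nM, with a range from 35000 nM to 160000 nM. The expected step of a 1.4-fold lower number from compound 3 to compound 4 (0.14 log units; within the scatter) should stay within the scatter.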

Compound 4, half-maximal cytotoxic concentration: 86600 nM
Beside the measured number, compound 4's estimate is 1.2-fold (0.06 log units) below it; low and high end bracket the measured number.
By their numbers in this assay, from the lowest: compounds 2, 4, 1 and 3 (each within the scatter of the next, the first and the last beyond it).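

In this assay, a third group has now been read on a saturated chain carbon bound to a saturated ring carbon, and 3-nitrophenyl in place of 4-(trifluoromethyl)phenyl gives a 1.2-fold lower number from compound 3 to compound 4 (0.08 log units; within the scatter) even though both the ring substituent and its location on the ring differ. The nitro group in place of the amidoxime on an aromatic carbon gives a 1.7-fold higher number from compound 2 to compound 4 (0.24 log units; within the scatter) as well, so among these three groups only compound 2 and compound 3 stand apart beyond the scatter, and compound 4 cannot be told apart from either of them. Nothing measured alongside these numbers accounts for them.

The compounds shown leave open whether a group of another kind on this ring, such as an amine or a carboxylic acid, or a longer chain between the ring and the shared core, would move the number beyond this narrow band. They also do not separate the substituent from its location on the ring, as a 4-nitrophenyl or a 3-(trifluoromethyl)phenyl group would.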